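The source may hold more compounds than are shown below. What is called first, only, known or untested is meant among the compounds shown, and "the series" means these compounds.

Measured in a functional assay on NCI-H460 cells (Homo sapiens) for antiproliferative activity, read by sulforhodamine B assay, with a stated time of 48 h; a higher number here means a weaker inhibitor of growth, a lower number a stronger inhibitor of growth:
- compound 1 `CCCCCC[C@@H](O)C/C=C\CCCCCCCC(=O)N[C@@H](C)c1ccccc1`: 8.3 ug/mL
- compound 2 `CCCCCCCC/C=C\CCCCCCCC(=O)N1CCCC1`: 45.6 ug/mL

Compound 2 has the higher of the two numbers, and its gap to compound 1 lies beyond the scatter. Compound 3 `CCCCCCCC/C=C\CCCCCCCC(=O)N1CCCCC1` has piperidin-1-yl in place of pyrrolidin-1-yl on a carbonyl carbon. Among the measured compounds shown here, no step between measured compounds gives the size of this change. In this assay, the expectation is therefore a small move toward lower numbers, with nothing beyond the scatter. The expected step is a 1.1-fold lower number from compound 2 to compound 3 (0.06 log units; within the scatter). For compound 3 the estimated value is 40 ug/mL, with an expected range of 20 ug/mL to 80 ug/mL.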

Compound 3, concentration for 50% growth inhibition: 23 ug/mL
Compound 3: middle estimate off by 1.7-fold (0.24 log units), on the high side; the range from low to high includes it.
By their numbers in this assay, from the lowest: compound 1; then compounds 3 and 2 (each within the scatter of the next).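

In this assay, among the compounds shown here, this is the first reading of the change on a carbonyl carbon: piperidin-1-yl in place of pyrrolidin-1-yl gives a step that stays within the scatter (a 2.0-fold lower number from compound 2 to compound 3 (0.30 log units; within the scatter)). The six-membered and five-membered non-aromatic rings are therefore not separated at this position in this assay. No measurement gives a reason for this result.

Still open, from the compounds shown here alone, is how a morpholine ring or an open-chain diethylamino group would read on the same carbonyl carbon. Also open, going by these compounds, is what the chain hydroxyl of compound 1 would do on the core of compound 3.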